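The source may report more compounds than this note shows. Statements on the series, on what has been measured and on what is new or still open speak of the compounds shown alone.

Measured so far in a physicochemical assay for solubility, read by spectrophotometry, in phosphate buffer, with a stated time of 18 h, at pH 7.4; on this read-out lower numbers stand for lower solubility and higher numbers for higher solubility:
- Compound 1 `CCc1ccc(-c2nc3c(c(C)nn3-c3ccccc3)c(-c3ccccc3)c2C#N)cc1`: 47000 nM
- Compound 2 `Cc1nn(-c2ccccc2)c2nc(-c3ccc(C(C)C)cc3)c(C#N)c(-c3ccccc3O)c12`: 9800 nM

Of these two compounds, compound 2 has the lower number, and the gap up to compound 1 is larger than the usual scatter of repeated measurements. The two structures differ in more than one place, so this gap cannot be assigned to any single change.

The next compound, compound 3 `Cc1nn(-c2ccccc2)c2nc(-c3ccc(I)cc3)c(C#N)c(-c3ccccc3O)c12`, differs from compound 2 in one place. It has iodo in place of isopropyl on an aromatic carbon, para to a large group, so 4-isopropylphenyl becomes 4-iodophenyl (iodo in place of isopropyl on an aromatic carbon). The rest of the structure stays the same.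

Among the measured compounds shown here, no measured pair here shows what this exchange does, which leaves compound 2 at 9800 nM as the only close reference point. A slight drop is expected, with a step no larger than the scatter: the estimated step is a 1.2-fold lower number from compound 2 to compound 3 (0.09 log units; within the scatter). This expectation is tentative. For compound 3, the estimate in this assay is 8000 nM, with an expected range from 2000 nM to 30000 nM.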

Compound 3, solubility: 1500 nM
The estimate for compound 3 lay 5.3-fold (0.73 log units) above the measured number, outside the stated range (below it).
By their numbers in this assay, from the lowest: compound 3; then compound 2; then compound 1.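

Among the compounds shown here, this pair is the first in the set to differ in only one place, so a change in the number can be tied to a single exchange, which the two earlier compounds did not allow. In this assay, putting iodo in place of isopropyl on an aromatic carbon, para to a large group, gives a 6.5-fold lower number from compound 2 to compound 3 (0.82 log units; beyond the scatter) and shows that the result is sensitive to what sits at this place, even with the rest of the structure unchanged. The counted differences show three carbon atoms leaving and one iodine entering, with no hydrogen-bond donor, hydrogen-bond acceptor or net charge on either side, and nothing measured here explains the shift.

From the compounds shown here alone, with a single pair, it stays open whether the lower number follows from the arrival of iodo or from the loss of isopropyl. Other groups at this place, such as a methoxy group, an amine or a carboxylic acid, would show whether the number tracks a wider pattern or whether this exchange stands alone.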